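The source may hold more compounds than are shown below. What is called first, only, known or untested is meant among the compounds shown, and "the series" means these compounds.

Measured so far:
compound 1, `Cc1c(OCCCCOCOc2ccc(C(=O)O)cc2)ccc(C(=O)CC2CCCC2)c1O`: 228 nM
compound 2, `Cc1c(OCCCCOc2ccccc2C(=O)O)ccc(C(=O)CC2CCCC2)c1O`: 335 nM

Both compounds were tested in an assay on HEK293 cells for positive allosteric modulation of metabotropic glutamate receptor 2 (Rattus norvegicus), read by thallium flux, with a stated time of 2.5 min; on this read-out higher numbers stand for an effect only at larger amounts of compound and lower numbers for an effect already at smaller amounts. Compound 2 gives 335 nM in this assay and has the highest of the two numbers, with compound 1 as its nearest neighbour at 228 nM; the difference, a 1.5-fold higher number from compound 1 to compound 2 (0.17 log units; within the scatter), is within the scatter, so the two cannot be told apart. Compound 3, `Cc1c(OCCCCOc2ccc(C(=O)O)cc2Cl)ccc(C(=O)CC2CCCC2)c1O`, is not yet measured. It differs from compound 2 by 4-carboxy-2-chlorophenyl in place of 2-carboxyphenyl on an oxygen on a saturated carbon. Within the data shown here, the only step that bears on this is the one from compound 1 to compound 2, where the carboxy group moved between positions on the aromatic ring and the spacer changed, with no effect beyond the scatter. Among the measured compounds shown here, no measured step involves a chlorine. On this thin basis, no step beyond the scatter is expected for compound 3 in this assay, which a 1.1-fold lower number from compound 2 to compound 3 (0.05 log units; within the scatter) expresses. The estimate for compound 3 is 300 nM, with a range from 100 nM to 900 nM.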

Compound 3, half-maximal effective concentration: 237 nM
The estimate for compound 3 lay 1.3-fold (0.10 log units) above the measured number, within the range that was stated.
By their numbers in this assay, from the lowest: compounds 1, 3 and 2 (each within the scatter of the next).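

In this assay, replacing 2-carboxyphenyl with 4-carboxy-2-chlorophenyl gives a 1.4-fold lower number from compound 2 to compound 3 (0.15 log units; within the scatter), so this place on the oxygen carries a ring chlorine, the first in the series, without a step beyond the scatter. Replacing (4-carboxyphenoxy)methyl with the same group gives a 1.0-fold higher number from compound 1 to compound 3 (0.02 log units; within the scatter), so all three groups tried at this place give numbers that cannot be told apart. No measurement here explains why these groups give such similar numbers.

Compound 3 differs from compound 2 both in the position of the carboxy group and in the added chlorine, so the contribution of each change cannot be separated. On these data alone, it also remains open what a bromine in place of the chlorine, or an amine in place of the carboxylic acid, would do at this place.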